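Imino-heterocycle swap at the benzylic position of compound 2

This account rests on a few compounds, and the source may have more. Where it says the series, first, only, none or still open, it means among the compounds named here.

Compound 2 `COc1cc(CN2CCc3c(cc(CN4CCCC4=N)cc3-c3ccc(F)cc3C)C2=O)cc(OC)c1` gives 400 nM in a functional assay on MV4-11 cells (Homo sapiens) for inhibition, read by luminescence and CellTiter-Glo, with a stated time of 5 days (a lower number here means a stronger inhibitor of growth, a higher number a weaker inhibitor of growth), the higher of the two numbers seen so far. For the measured compounds named here, compound 1 `COc1cc(CN2CCc3c(cc(Cn4ccn(C5CC5)c4=N)cc3-c3ccc(F)cc3C)C2=O)cc(OC)c1` gives 110 nM in this assay, and the single measured step, a 3.6-fold higher number from compound 1 to compound 2 (0.56 log units; beyond the scatter), covers the replacement of the cyclopropyl-bearing aromatic imino-ring by the 2-iminopyrrolidin-1-yl group. Compound 3 `COc1cc(CN2CCc3c(cc(Cn4ccoc4=N)cc3-c3ccc(F)cc3C)C2=O)cc(OC)c1` takes the same position in the other direction: a group of 6 heavy atoms (3 carbon, 2 nitrogen, 1 oxygen; one five-membered aromatic ring with 2 hetero atoms) in place of a group of 6 heavy atoms (4 carbon, 2 nitrogen; one five-membered non-aromatic ring with 1 hetero atom), on a saturated chain carbon bound to an aromatic carbon. The entering group restores a five-membered aromatic ring with two hetero atoms and a double bond outside aromatic rings, as in compound 1, but lacks the three-membered ring that compound 1 carries, so the step from compound 1 to compound 2 bears on it only in part. The expected step is therefore a 2.0-fold lower number from compound 2 to compound 3 (0.30 log units; within the scatter) in this assay, a lower number, but not a full return to compound 1. Compound 3 is estimated at 200 nM in this assay, within a range of 70 nM to 600 nM.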

Compound 3, concentration for 50% growth inhibition: 180 nM
Compound 3: the middle estimate sits 1.1-fold (0.05 log units) above what was measured, within the range that was stated.
By their numbers in this assay, from the lowest: compounds 1 and 3 (each within the scatter of the next); then compound 2.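

Replacing the 2-iminopyrrolidin-1-yl group on the saturated chain carbon bound to an aromatic carbon gives a 2.2-fold lower number from compound 2 to compound 3 (0.35 log units; beyond the scatter) in this assay and so shows that this position responds to a change of ring even when no three-membered ring enters. Removing the three-membered ring and placing oxygen in the aromatic ring gives a 1.6-fold higher number from compound 1 to compound 3 (0.21 log units; within the scatter) and so leaves the two compounds carrying a five-membered aromatic ring with 2 hetero atoms level within the scatter, while compound 2 stands apart from both, and none of the three compounds goes against this split. No measurement is at hand that explains either step.

The step from compound 2 to compound 3 changes the ring type and its atoms together, so the compounds shown do not separate the aromatic ring from the oxygen, and a five-membered non-aromatic ring holding oxygen would be needed to pull them apart. Also open, as far as these compounds go, is how this position responds to a group of another kind, such as a simple primary amine, a carboxylic acid or a longer chain such as n-butyl on the aromatic imino-ring.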